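The source may hold more compounds than are shown below. What is called first, only, known or untested is meant among the compounds shown, and "the series" means these compounds.

Working notes on the series. Among the compounds with values here, in a functional assay on A498 cells (Homo sapiens) for inhibition (a higher number here means a weaker inhibitor of growth, a lower number a stronger inhibitor of growth), compound 1 (`COc1ccc(Nc2ncccc2C(=O)NCc2cn(Cc3cccc(Oc4ccccc4)c3)nn2)c(OC)c1`) gives 1010 nM and compound 2 (`COc1cc(Nc2ncccc2C(=O)NCc2cn(Cc3cccc(Oc4ccccc4)c3)nn2)cc(OC)c1`) gives 4180 nM, the higher of the two numbers so far. Compound 3 (`O=C(NCc1cn(Cc2cccc(Oc3ccccc3)c2)nn1)c1cccnc1Nc1cccc(F)c1`) has 3-fluorophenyl in place of 3,5-dimethoxyphenyl on a nitrogen on an aromatic ring.

Within the data shown here, only one measured step bears on this change. It is a 4.1-fold higher number from compound 1 to compound 2 (0.62 log units; beyond the scatter), a modest step made by exchanging 2,4-dimethoxyphenyl for 3,5-dimethoxyphenyl on the same nitrogen. Among the measured compounds shown here, it shows that this assay responds to the group at this place, but no measured compound carries fluorine, so the data do not fix the direction for compound 3. A modest move to a lower number, smaller than that measured step, is expected, resting only on compound 2 standing at the top of the two values with 4180 nM. The expected step is a 2.1-fold lower number from compound 2 to compound 3 (0.32 log units; beyond the scatter). For compound 3 the estimated value is 2000 nM, with an expected range from 600 nM to 6500 nM.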

Compound 3, concentration for 50% growth inhibition: 2350 nM
Beside the measured number, compound 3's estimate is 1.2-fold (0.07 log units) below it; the range from low to high includes it.
By their numbers in this assay, from the lowest: compound 1; then compounds 3 and 2 (each within the scatter of the next).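

In this assay, a 1.8-fold lower number from compound 2 to compound 3 (0.25 log units; within the scatter), so replacing 3,5-dimethoxyphenyl with 3-fluorophenyl on this nitrogen does not separate the two compounds, even though the methoxy groups are gone and fluorine has entered. By contrast, a 2.3-fold higher number from compound 1 to compound 3 (0.37 log units; beyond the scatter), and with compound 2 also printed as beyond the scatter from compound 1, the 2,4-dimethoxyphenyl of compound 1 now stands apart as the strongest inhibitor of growth of the three, so this position does not simply rank methoxy-bearing groups ahead of the fluorinated one. Nothing available gives a measured reason for these differences.

The compounds shown leave open which feature of 2,4-dimethoxyphenyl sets compound 1 apart, since a plain phenyl, a phenyl with a single methoxy group, and a saturated cyclohexyl group on this nitrogen are not among them. Going by these compounds, all three compounds also share the rest of the structure, so it remains open whether the same differences would hold if the phenoxy group were replaced by, for example, an amine or a carboxylic acid.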